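Ethoxy in place of methylamino on the carbonyl carbon

The compounds below may be only part of what the source reports. "The series", "measured", "known", "first", "only" and "open" are said of these compounds alone.

Series so far in a functional assay on HCT-116 cells (Homo sapiens) for inhibition, read by MTT assay, with a stated time of 72 h; on this read-out lower numbers stand for stronger inhibition of growth and higher numbers for weaker inhibition of growth 
- compound 1 `CNC(=O)/C=C/c1ccncc1-c1ccc2ccccc2c1` reads 6550 nM 
- compound 2 `CNC(=O)/C=C/c1ccncc1-c1ccc2cccnc2c1` reads "not determined" (no result reported) 
- compound 3 `O=C(COc1ccncc1-c1ccc2ccccc2c1)N1CCOCC1` reads "not determined" (no result reported) 

For the measured compounds named here, compound 1 holds the only number, so it cannot be ranked against anything: compounds 2 and 3 offer no result for comparison. Still unmeasured is compound 4 `CCOC(=O)/C=C/c1ccncc1-c1ccc2ccccc2c1` which keeps the core of compound 1 and differs in one group. The change is ethoxy in place of methylamino on a carbonyl carbon and in words it puts ethoxy in place of methylamino on a carbonyl carbon, so methylcarbamoyl becomes ethoxycarbonyl.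

Going by the values given here, no pair of measured compounds shows what a single change does here. In this assay no step beyond the usual scatter is expected, and neither direction is firmly favoured. The sole anchor for this expectation is compound 1 at 6550 nM and the range stays wide for that reason. The estimated move is a 1.3-fold lower number from compound 1 to compound 4 (0.12 log units; within the scatter) and it remains an expectation only. Compound 4 is expected at 5000 nM (estimated range 1500 nM to 15000 nM).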

Compound 4, concentration for 50% growth inhibition: 910 nM
The estimate for compound 4 lay 5.5-fold (0.74 log units) above the measured number; measured number outside the range, below it.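

In this assay, for the compounds shown here, the group on the carbonyl carbon proves able to shift the read-out: ethoxy in place of methylamino gives a 7.2-fold lower number from compound 1 to compound 4 (0.86 log units; beyond the scatter), the first step that can be read. The change swaps the hydrogen-bond donor of methylamino for the hydrogen-bond acceptor of ethoxy and also enlarges the group, and this single step cannot separate those differences. No measured evidence accounts for the step.

Open, on these data alone, is whether the lower number belongs to ethoxycarbonyl specifically or extends to other groups on the same carbonyl carbon, such as methoxy, a longer alkoxy chain or a carboxylic acid. Dimethylamino, an amide without the amide hydrogen, would test the loss of the donor apart from the change to an ester.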